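The compounds below may be only part of what the source reports. "The series", "measured", "known", "first", "only" and "open" are said of these compounds alone.

In a functional assay on thoracic aorta for antagonist activity at thromboxane A2 receptor (Rattus norvegicus) (on this read-out higher numbers stand for weaker inhibition and lower numbers for stronger inhibition), compound 2 `CC(C)c1ccc2c(CCCC(=O)NS(=O)(=O)c3ccc(Cl)cc3)cc(C(=O)O)c-2cc1` gives 19000 nM, the higher of the two numbers seen here. Compound 1 `CC(C)c1ccc2c(CCCCCS(=O)(=O)Nc3ccccc3)cc(S(=O)(=O)O)c-2cc1` gives 1400 nM, a gap beyond the scatter, though the two structures differ in more than one place. Compound 3 `CC(C)c1ccc2c(CCCC(=O)NS(=O)(=O)c3ccc(Cl)cc3)cc(S(=O)(=O)O)c-2cc1` keeps the chain and acylsulfonamide of compound 2 and carries sulfo in place of carboxy on an aromatic carbon. Within the data shown here, no measured pair isolates this exchange, so the size of the step is open; compound 1, which also bears a sulfo group, gives 1400 nM in this assay, which points toward a lower number. A step of a 4.8-fold lower number from compound 2 to compound 3 (0.68 log units; beyond the scatter) is expected. Compound 3 is estimated at 4000 nM, between 900 nM and 15000 nM.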

Compound 3, half-maximal inhibitory concentration: 54000 nM
Estimate against measurement, compound 3: 14-fold (1.13 log units) below; measured number above the stated range.
By their numbers in this assay, from the lowest: compound 1; then compound 2; then compound 3.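

On the chain and acylsulfonamide of compound 2, sulfo in place of carboxy on this aromatic carbon gives, in this assay, a 2.8-fold higher number from compound 2 to compound 3 (0.45 log units; beyond the scatter). At this place, then, a sulfo group does not by itself give a low number on this chain. Nothing in hand explains the direction of this step. The compounds shown leave open whether the same exchange would run the same way on the chain of compound 1, and how a tetrazole or a phosphonic acid at this place would read.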